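The source may report more compounds than this note shows. Statements on the series, on what has been measured and on what is new or still open speak of the compounds shown alone.

Working notes on the series. The shared core is carried by compound 1 `Cc1ccc(NC2=CC(=O)c3c(nc4n3[C@H]3OC[C@@H](O)[C@H]3OC4)C2=O)cc1C`, compound 2 `O=C1C(NC2CC2)=CC(=O)c2c1nc1n2[C@H]2OC[C@@H](O)[C@H]2OC1`, compound 3 `O=C1C(NC2CCCC2)=CC(=O)c2c1nc1n2[C@H]2OC[C@@H](O)[C@H]2OC1` and the not yet measured compound 4 `O=C1C(N2CCCC2)=CC(=O)c2c1nc1n2[C@H]2OC[C@@H](O)[C@H]2OC1`. In a functional assay on HeLa cells (Homo sapiens) for inhibition, read by sulforhodamine B assay (a lower number here means a stronger inhibitor, a higher number a weaker inhibitor), compound 1 gives 4320 nM. For compound 2 the value of > 16000 nM is a limit of the assay, not a number. For compound 3 the value of > 16000 nM is likewise only a limit. Compound 3 therefore stands at the limit of > 16000 nM in this assay, at which 2 of the 3 values shown sit; an at least 3.7-fold higher number from compound 1 to compound 3 (0.56 log units; beyond the scatter), matching an at least 3.7-fold higher number from compound 1 to compound 2 (0.56 log units; beyond the scatter), while a step that the two limits leave unreadable from compound 2 to compound 3. The change to compound 4 is pyrrolidin-1-yl in place of cyclopentylamino on a double-bonded ring carbon. For the measured compounds named here, no measured step of this kind exists, and the nearest values are both limits. For compound 4 the expected step is a number no higher from compound 3 to compound 4 (the limit leaves the size open), none beyond the scatter. Compound 4 is estimated at 16000 nM, within 6000 nM to 40000 nM, likely again reported only as a limit.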

Compound 4, half-maximal inhibitory concentration: > 16000 nM
Compound 4 ended at the assay's limit (the forecaster's own chance of this, stated with the estimate: 65%); the middle value sits exactly at the limit.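

Losing the amine hydrogen, with pyrrolidin-1-yl in place of cyclopentylamino, does not lift the series off the limit, so compound 4 adds a ring nitrogen without a hydrogen-bond donor to the groups at the ceiling of this assay: the limit of > 16000 nM in this assay, at which 3 of the 4 values shown sit. The steps among compounds 2, 3 and 4 cannot be read. Of the groups on this double-bonded ring carbon, only (3,4-dimethylphenyl)amino gives a real number, with an at least 3.7-fold higher number from compound 1 to compound 4 (0.56 log units; beyond the scatter).

Any order among the three limited compounds stays hidden. Going by these compounds, whether a benzylamino or a plain phenylamino group would give a measurable value remains open.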